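The source may hold more compounds than are shown below. What is called first, only, known or untested is meant among the compounds shown, and "the series" means these compounds.

The measured compounds:
Compound 1, `C/C(=C\c1cc(-c2cccnc2)co1)C(N)=O`, in an ADME assay on NIH3T3 cells (Mus musculus) for cytotoxicity, read by CCK-8 assay, with a stated time of 24 h (a lower number here means a stronger inhibitor, a higher number a weaker inhibitor), gives > 50000 nM.
Compound 2, `C/C(=C\c1cc(-c2ccc(C)nc2)co1)C(N)=O`, in this assay gives > 50000 nM.
Compound 3, `C/C(=C\c1nc(-c2ccccc2)cs1)C(N)=O`, in this assay gives > 50000 nM.

Each of these values is a limit of this assay and not a number. Compound 2 differs from compound 1 by methyl in place of hydrogen on an aromatic carbon. The step that the two limits leave unreadable from compound 1 to compound 2 is therefore not readable in size. Compound 3 carries the same side chain as compound 1 on a different core; the difference between the two cores is not broken down here.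

Compound 4, `C/C(=C\c1nc(-c2ccc(C)cc2)cs1)C(N)=O`, has not yet been measured in this assay. It differs from compound 3 by methyl in place of hydrogen on an aromatic carbon. This is the same kind of change as that from compound 1 to compound 2, though the place is not the same word for word: in compound 2 the methyl enters a six-membered aromatic ring with 1 nitrogen, next to the ring nitrogen, while in compound 4 the ring is of carbon only.

For compound 4 the expected step is a step that the limit leaves unreadable from compound 3 to compound 4, resting on (the limit of > 50000 nM in this assay, at which 3 of the 3 values shown sit). Compound 4 is thus estimated at 80000 nM, most likely again only a limit.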

Compound 4, half-maximal inhibitory concentration: > 50000 nM
Compound 4: no number, only a limit (the forecaster's own chance of this, stated with the estimate: 85%); the middle value is on the limit's open side.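

Compound 3 and compound 4 both give only a limit in this assay and not a number, so the size of the step between them, methyl in place of hydrogen, cannot be read. The compounds shown leave open how any of them truly ranks in cytotoxicity, since all stand at the same limit: the limit of > 50000 nM in this assay, at which 4 of the 4 values shown sit.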